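Swapping One Aromatic Group: From Compound 1 to Compound 4

A few compounds are considered here, and "the series" means these few. Any claim that something is new, unique, unknown or untested is made for them only; others in the source may bear on it.

In a functional assay on HCT-15 cells (Homo sapiens) for inhibition, read by sulforhodamine B assay, with a stated time of 48 h (a lower number here means a stronger inhibitor of growth, a higher number a weaker inhibitor of growth), compound 1 (`O=C(Nc1cccc(-n2cc(-c3ccncc3)c(-c3ccc(Cl)c(O)c3)n2)c1)Nc1cccc(C(F)(F)F)c1`) gives 1510 nM and stands level, within the scatter, with compound 3 (`COc1cc(-c2nn(-c3cccc(NC(=O)Nc4ccc(Cl)c(Cl)c4)c3)cc2-c2ccncc2)ccc1Cl`) at 1230 nM in the same test. Compound 2 (`COc1cc(-c2nn(-c3cccc(NC(=O)Nc4cc(C(F)(F)F)cc(C(F)(F)F)c4)c3)cc2-c2ccncc2)ccc1Cl`) gives 617 nM as its number, which is lower than that of compound 1 by more than the scatter. Compound 1 therefore sits with compound 3 at the weaker end of this small set.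

Compound 4 (`O=C(Nc1cccc(-n2cc(-c3ccncc3)c(-c3ccc(Cl)c(O)c3)n2)c1)Nc1ccc(Cl)c(Cl)c1`) keeps the core of compound 1 but has 3,4-dichlorophenyl in place of 3-(trifluoromethyl)phenyl on an amide-type nitrogen. For the measured compounds named here, no pair of measured compounds isolates this swap, so there is no direct step to go by. The nearest guide is compound 3, which carries the same 3,4-dichlorophenyl on a core that differs elsewhere and gives 1230 nM with it, level with compound 1. The expected step of a 1.2-fold lower number from compound 1 to compound 4 (0.07 log units; within the scatter) in this assay is therefore small, with nothing beyond the scatter anticipated. Compound 4 is expected at 1300 nM with an estimated range from 600 nM to 2800 nM overall.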

Compound 4, concentration for 50% growth inhibition: 1230 nM
For compound 4 the middle estimate is 1.1-fold (0.02 log units) above the measured one; the range from low to high includes it.
By their numbers in this assay, from the lowest: compounds 2, 3, 4 and 1 (each within the scatter of the next, the first and the last beyond it).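

For the compounds shown here, the first direct pair for this swap shows that, on the core of compound 1, 3,4-dichlorophenyl in place of 3-(trifluoromethyl)phenyl on an amide-type nitrogen gives a 1.2-fold lower number from compound 1 to compound 4 (0.09 log units; within the scatter) in this assay, so this test does not tell these two groups apart at this position. A second change can now also be read: hydrogen in place of methyl on an oxygen on an aromatic ring gives no change at the digits printed from compound 3 to compound 4 (within the scatter), so with 3,4-dichlorophenyl in place, that change also leaves the number within the scatter. Nothing available here explains either result.

Both pairs swap groups that leave the number level, so they do not show how far this position tolerates change. On these data alone, whether an amine or a carboxylic acid on the phenyl ring, or a longer alkyl chain in place of that ring, would move the number beyond the scatter remains open.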